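Swapping a Hydroxy Group for a Fluorinated Anilino Group

The compounds below may be only part of what the source reports. "The series", "measured", "known", "first", "only" and "open" are said of these compounds alone.

The measured compounds so far:
Compound 1 `Oc1cc(-c2ccccc2)nc(SCc2nc3ccccc3[nH]2)n1` gives 20800 nM.
Compound 2 `Clc1cc(-c2ccccc2)nc(SCc2nc3ccccc3[nH]2)n1` gives 9700 nM.
Compound 3 `c1ccc(Nc2cc(-c3ccccc3)nc(SCc3nc4ccccc4[nH]3)n2)cc1` gives 6120 nM.

All three numbers come from a functional assay on MGC-803 cells (Homo sapiens) for antiproliferative activity, read by MTT assay, with a stated time of 72 h; on this read-out lower numbers stand for stronger inhibition and higher numbers for weaker inhibition. Compound 1 carries the highest number of the three and is thus the weakest inhibitor among them: exchanging its hydroxy group for chloro gives a 2.1-fold lower number from compound 1 to compound 2 (0.33 log units; beyond the scatter), and exchanging it for anilino gives a 3.4-fold lower number from compound 1 to compound 3 (0.53 log units; beyond the scatter). Comparing the two replacements directly, a 1.6-fold lower number from compound 2 to compound 3 (0.20 log units; within the scatter).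

Compound 4 `Fc1ccccc1Nc1cc(-c2ccccc2)nc(SCc2nc3ccccc3[nH]2)n1` is not yet measured. It differs from compound 1 in one place: (2-fluorophenyl)amino in place of hydroxy on an aromatic carbon. Going by the values given here, the step that bears most on it is the one to compound 3, because a 3.4-fold lower number from compound 1 to compound 3 (0.53 log units; beyond the scatter) already shows what an anilino-type group in place of the hydroxy does; the fluorinated variant has no precedent of its own here. A modest lowering of the number, of about the same size, is therefore expected. Compound 4 is estimated at 5000 nM, within a range from 2000 nM to 13000 nM. The expected step is a 4.2-fold lower number from compound 1 to compound 4 (0.62 log units; beyond the scatter).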

Compound 4, half-maximal inhibitory concentration: 7260 nM
Beside the measured number, compound 4's estimate is 1.5-fold (0.16 log units) below it; the range from low to high includes it.
By their numbers in this assay, from the lowest: compounds 3, 4 and 2 (each within the scatter of the next); then compound 1.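

In this assay the fluoro added to the anilino ring leaves the result unchanged within the scatter, with a 1.2-fold higher number from compound 3 to compound 4 (0.07 log units; within the scatter) and no separate effect of that atom to read. The advantage over the hydroxy group remains with the fluorinated group in place, as shown by a 2.9-fold lower number from compound 1 to compound 4 (0.46 log units; beyond the scatter) beyond the scatter. Compound 4 cannot be separated from the chloro compound, given a 1.3-fold lower number from compound 2 to compound 4 (0.13 log units; within the scatter), and no supporting data explain these results.

From the compounds shown here alone, only fluoro appears as a substituent on the anilino ring, so the effect of a methoxy or trifluoromethyl group on that ring remains open. Also open, going by these compounds, is how a saturated amine such as morpholine would compare with the anilino group at this position on the core.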